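This account rests on a few compounds, and the source may have more. Where it says the series, first, only, none or still open, it means among the compounds named here.

The measured compounds:
compound 1, `O=C(C1CCC1)N1CCCn2nc(COc3ccccc3)cc21`, gives 41% in a functional assay on HEK293 cells for positive allosteric modulation of metabotropic glutamate receptor 5 (Homo sapiens), read by calcium flux; on this read-out higher numbers stand for larger maximal responses and lower numbers for smaller maximal responses
compound 2, `O=C(c1ccco1)N1CCCn2nc(COc3ccccc3)cc21`, gives < 15% in this assay

Compound 2 stands at the bottom of what this assay can report: the value < 15% is a limit of the assay, not a measured number. This limit is the limit of < 15% in this assay, at which 1 of the 2 values shown sits. Within the data shown here, the one measured step, a number at least 26 percentage points lower from compound 1 to compound 2 (beyond the scatter), came with furan-2-yl in place of cyclobutyl on the carbonyl carbon.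

Compound 3, `O=C(c1ccno1)N1CCCn2nc(COc3ccccc3)cc21`, keeps that carbonyl and changes only the ring on it: 1,2-oxazol-5-yl in place of furan-2-yl on a carbonyl carbon. Among the measured compounds shown here, no measured step covers this exchange of one five-membered aromatic ring for another. For the measured compounds named here, the only step known, a number at least 26 percentage points lower from compound 1 to compound 2 (beyond the scatter), tells that an aromatic ring on the carbonyl carbon went with a smaller response than cyclobutyl, and nothing measured separates 1,2-oxazol-5-yl from furan-2-yl. With compound 2 already at the limit < 15%, a further downward step could not be seen. The expected step that the limit leaves unreadable from compound 2 to compound 3 is therefore none beyond the scatter. Compound 3 is expected to give about 14% in this assay, between 4% and 32%, quite possibly again only as a limit.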

Compound 3, largest response reached (reported as percent of maximum), in percent of the reference or control that the assay uses: 22%
Estimate against measurement, compound 3: 8 percentage points below, within the range that was stated.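

Among these compounds, compound 3 gives the first real number for an aromatic ring on this carbonyl carbon: it gives 22% in this assay, so the exchange of cyclobutyl for such a ring can now be sized as a number 19 percentage points lower from compound 1 to compound 3 (beyond the scatter). The comparison between the two aromatic rings is much less firm, with a number at least 7 percentage points higher from compound 2 to compound 3 (that floor lies within the scatter), so the data do not show that 1,2-oxazol-5-yl gives a larger response than furan-2-yl. The true size of that step cannot be read because compound 2 carries a limit and not a number: the limit of < 15% in this assay, at which 1 of the 3 values shown sits.

All three compounds share the same core and differ only in the group on the carbonyl carbon, so they cannot show whether these exchanges would hold on a different core. On these data alone, it also stays open how the response would change with a six-membered aromatic ring such as pyridin-2-yl, a larger saturated ring such as cyclopentyl, or an open chain such as butyl in place of cyclobutyl on that carbon.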